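Swapping one group on compound 1 for 2-phenylethenyl

The compounds below may be only part of what the source reports. "The series", "measured", "known", "first", "only" and "open" are said of these compounds alone.

In a functional assay on cells (Mast cell, Rattus norvegicus) for inhibition (on this read-out lower numbers stand for stronger inhibition and higher numbers for weaker inhibition), compound 1 (`OC1c2ccccc2CCC1(Cc1ccccc1)C1=Cc2ccccc2C1`) gives 4100 nM and compound 2 (`O=C1c2ccccc2CCC1C1=Cc2ccccc2CC1`) gives 8000 nM in the same test. These two values lie within the usual scatter of each other, so neither compound can be ranked above the other. Compound 3 (`OC1c2ccccc2CCC1(/C=C/c1ccccc1)Cc1ccccc1`) keeps the core of compound 1 and changes one group: a group of 8 heavy atoms (8 carbon; one six-membered aromatic ring of carbon only) in place of a group of 9 heavy atoms (9 carbon; one five-membered non-aromatic ring of carbon only, one six-membered aromatic ring of carbon only), on a saturated ring carbon on a saturated ring carbon next to the ring atom that bears a hydroxy group. Both groups hold one six-membered aromatic ring, while only the leaving group holds the five-membered non-aromatic ring. Within the data shown here, no two measured compounds differ in just one place, so no measured step guides the size of this change. The estimated step of a 1.2-fold higher number from compound 1 to compound 3 (0.09 log units; within the scatter) in this assay is expected to stay within the scatter, with no clear direction. For compound 3 the estimate is 5000 nM (expected range 1800 nM to 14000 nM).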

Compound 3, half-maximal inhibitory concentration in the Mast cell assay: 55300 nM
Compound 3: middle estimate off by 11-fold (1.04 log units), on the low side; the measured number lies above the stated range.
By their numbers in the Mast cell assay, from the lowest: compounds 1 and 2 (each within the scatter of the next); then compound 3.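

In the Mast cell assay, where compound 1 gives 4100 nM and compound 3 gives 55300 nM, placing 2-phenylethenyl on this saturated ring carbon gives a 13-fold higher number from compound 1 to compound 3 (1.13 log units; beyond the scatter) and is the first clear change in inhibition among these compounds, so this position does respond to the group it carries. Both the leaving and the entering group hold one six-membered aromatic ring and one double bond outside aromatic rings, so these shared features alone do not preserve the inhibition, while in a physicochemical assay for lipophilicity (a lower number here means a more polar compound, a higher number a more lipophilic compound), the same change gives a number 0.28 log units higher from compound 1 to compound 3 (within the scatter) as a result within the scatter. In the physicochemical assay compound 1 gives 6.3 and compound 3 gives 6.58. Nothing measured here explains the loss in inhibition.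

A single step cannot separate the loss of the five-membered non-aromatic ring from the other differences between the two groups. Going by these compounds, how an amine or a longer chain would behave on this carbon in the Mast cell assay also remains open.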